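Amide Nitrogen Carries a Benzyl Instead of an Aryl

A few compounds are considered here, and "the series" means these few. Any claim that something is new, unique, unknown or untested is made for them only; others in the source may bear on it.

Compound 3, `COc1cc(-c2nnc(SCC(=O)Nc3ccc(C)cc3)n2N)cc(OC)c1OC`, has been measured in a functional assay on PC-3 cells (Homo sapiens) for antiproliferative activity, read by MTT assay, with a stated time of 48 h (a lower number here means a stronger inhibitor, a higher number a weaker inhibitor), and gives 43100 nM. Of the two plain numbers recorded, this is the higher one, yet its nearest neighbour, compound 2 with structure `COc1cc(-c2nnc(SCC(=O)Nc3ccccc3)n2N)cc(OC)c1OC` and a value of 37900 nM, sits so close that the step of a 1.1-fold higher number from compound 2 to compound 3 (0.06 log units; within the scatter) cannot be told from repeat scatter. Compound 1, `COc1cc(-c2nnc(SCC(=O)c3ccc(F)cc3)n2N)cc(OC)c1OC`, reaches only a limit of this assay and gives > 100000 nM. Against that limit, the steps of an at least 2.6-fold lower number from compound 1 to compound 2 (0.42 log units; beyond the scatter) and an at least 2.3-fold lower number from compound 1 to compound 3 (0.36 log units; beyond the scatter) both count as gains in potency.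

Compound 4, `COc1cc(-c2nnc(SCC(=O)NCc3ccc(Cl)cc3)n2N)cc(OC)c1OC`, has not yet been measured. The change is 4-chlorobenzyl in place of 4-methylphenyl on an amide-type nitrogen. For the measured compounds named here, no measured step mirrors this change; the nearest guidance is a 1.1-fold higher number from compound 2 to compound 3 (0.06 log units; within the scatter), which shows that swapping a group on an aromatic carbon left the number where it was. Compound 4 is therefore expected to show no step beyond the scatter, estimated at a 1.1-fold lower number from compound 3 to compound 4 (0.03 log units; within the scatter). The estimate for compound 4 in this assay is 40000 nM, with a range from 15000 nM to 120000 nM.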

Compound 4, half-maximal inhibitory concentration: > 100000 nM
Compound 4 ended at the assay's limit (the forecaster's own chance of this, stated with the estimate: 25%); middle value at least 2.5-fold (0.39 log units) from the limit.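

For the compounds shown here, until now the only change on the ring at this amide-type nitrogen was a methyl in place of hydrogen, and it left the number within the scatter, so the position showed no sensitivity. Going by these compounds alone, the move to 4-chlorobenzyl is the first change here to go beyond the scatter, and it weakens activity, with an at least 2.3-fold higher number from compound 3 to compound 4 (0.36 log units; beyond the scatter) and an at least 2.6-fold higher number from compound 2 to compound 4 (0.42 log units; beyond the scatter). In this assay the reading for compound 4 is a limit, as it is for compound 1, so the step between those two cannot be read: the limit of > 100000 nM in this assay, at which 2 of the 4 values shown sit.

This change brings in chlorine and also detaches the ring from direct attachment to the nitrogen, and the compounds shown cannot separate these two effects. As far as these compounds go, a plain benzyl, a 4-chlorophenyl group or a longer chain such as 2-phenylethyl on this nitrogen remains open.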